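A few compounds are considered here, and "the series" means these few. Any claim that something is new, unique, unknown or untested is made for them only; others in the source may bear on it.

In a functional assay on CHO cells for agonist activity at Free fatty acid receptor 1 (Homo sapiens), read by calcium flux (on this read-out lower numbers stand for an effect already at smaller amounts and higher numbers for an effect only at larger amounts of compound), compound 1 `Cc1cccc(-c2cccc(NC(=O)c3nnc(CCC(=O)O)s3)c2)c1` gives 760 nM. Compound 2 `O=C(O)CCc1nnc(C(=O)Nc2ccc(OCc3ccccc3)cc2)s1`, built on the same core but arranged differently, gives 17900 nM. Compound 3 `COc1ccc(NC(=O)c2nnc(COc3ccc(CCC(=O)O)cc3)s2)cc1` places the propanoic acid chain on an aryl ether and carries a 4-methoxyphenyl on the amide-type nitrogen. Within the data shown here, for compound 3 this assay reports only a limit, > 10000 nM, and that limit is where it stands among the numbers so far. One of the three values sits at that limit (the limit of > 10000 nM in this assay, at which 1 of the 3 values shown sits). Compound 4 `Cc1ccccc1NC(=O)c1nnc(COc2ccc(CCC(=O)O)cc2)s1` keeps the arrangement of compound 3 and differs in one place: 2-methylphenyl in place of 4-methoxyphenyl on an amide-type nitrogen, a 2-methylphenyl in place of a 4-methoxyphenyl. Among the measured compounds shown here, no step between two measured compounds isolates such an exchange, so its size is not known from this series, and the closest comparison, compound 3, gives no number at all. The expected step that the limit leaves unreadable from compound 3 to compound 4 in this assay is no more than the usual scatter, in either direction. Compound 4 is estimated at 15000 nM, with a range from 3000 nM to 60000 nM, and a limit rather than a number is the more likely outcome.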

Compound 4, half-maximal effective concentration: 1520 nM
The estimate for compound 4 lay 9.9-fold (0.99 log units) above the measured number, and the stated range ends above it.
By their numbers in this assay, from the lowest: compounds 1 and 4 (each within the scatter of the next); then compound 2.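

In this assay, 2-methylphenyl in place of 4-methoxyphenyl on an amide-type nitrogen gives an at least 6.5-fold lower number from compound 3 to compound 4 (0.81 log units; beyond the scatter), so the group on this nitrogen decides whether this arrangement gives a readable number. Compound 4, at 1520 nM, also shows that the propanoic acid chain on an aryl ether does not by itself rule out a measurable effect, which compound 3 alone could not show. Compound 3 carries a limit and not a number, so the step has only a lower bound and its full size stays unknown: the limit of > 10000 nM in this assay, at which 1 of the 4 values shown sits.

The exchange alters both the substituent and its numbered place on the aromatic ring, and this single pair does not separate the two. Going by these compounds, how an unsubstituted phenyl or a cyclohexyl on the same nitrogen would compare remains open.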